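Fluoro for hydrogen on the fused ring of compound 3

The compounds below may be only part of what the source reports. "The series", "measured", "known", "first", "only" and "open" are said of these compounds alone.

Measured compounds:
- compound 1, `CC#C[C@@H](CC(=O)O)c1ccc(OC[C@H]2COc3ccc(Cl)cc3O2)cc1`: 50 nM
- compound 2, `CC#C[C@@H](CC(=O)O)c1ccc(OC[C@H]2COc3c(Cl)cccc3O2)cc1`: 170 nM
- compound 3, `CC#C[C@@H](CC(=O)O)c1ccc(OC[C@H]2COc3ccccc3O2)cc1`: 90 nM

Three compounds sharing one core were measured in a functional assay on HEK293 cells for agonist activity at Free fatty acid receptor 1 (Homo sapiens), read by fluorescence and calcium flux, with a stated time of 10 min; on this read-out higher numbers stand for an effect only at larger amounts of compound and lower numbers for an effect already at smaller amounts. Compound 3, `CC#C[C@@H](CC(=O)O)c1ccc(OC[C@H]2COc3ccccc3O2)cc1`, gives 90 nM and stands second highest of the three numbers. Compound 1, `CC#C[C@@H](CC(=O)O)c1ccc(OC[C@H]2COc3ccc(Cl)cc3O2)cc1`, gives 50 nM, the nearest neighbour of compound 3; compound 2, `CC#C[C@@H](CC(=O)O)c1ccc(OC[C@H]2COc3c(Cl)cccc3O2)cc1`, gives 170 nM, the furthest. Both neighbours lie within the scatter of compound 3.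

The next compound, compound 4, `CC#C[C@@H](CC(=O)O)c1ccc(OC[C@H]2COc3ccc(F)cc3O2)cc1`, differs from compound 3 by fluoro in place of hydrogen on an aromatic carbon.

Among the compounds with values here, two measured steps bear on this change, each removing a chloro from an aromatic carbon of the fused ring: a 1.8-fold higher number from compound 1 to compound 3 (0.26 log units; within the scatter) and a 1.9-fold lower number from compound 2 to compound 3 (0.28 log units; within the scatter). Neither step rose beyond the scatter, so a halogen on this ring, at either of the two places tried, left the read-out of this assay essentially unchanged. A fluoro at the place now occupied is therefore expected to give no step beyond the scatter, and compound 4 is estimated at 70 nM, with a range from 30 nM to 160 nM, which means a step of a 1.3-fold lower number from compound 3 to compound 4 (0.11 log units; within the scatter) from compound 3 is expected.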

Compound 4, half-maximal effective concentration: 210 nM
Beside the measured number, compound 4's estimate is 3.0-fold (0.48 log units) below it; the whole stated range lies below it.
By their numbers in this assay, from the lowest: compounds 1, 3, 2 and 4 (each within the scatter of the next, the first and the last beyond it).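

At this aromatic carbon the two halogens do not behave alike: fluoro in place of hydrogen gives a 2.3-fold higher number from compound 3 to compound 4 (0.37 log units; beyond the scatter), whereas the chloro of compound 1 stood within the scatter of compound 3, so a halogen on this ring can no longer be treated as leaving the read-out unchanged. Within the data shown here, putting fluoro in place of chloro at the same carbon gives a 4.2-fold higher number from compound 1 to compound 4 (0.62 log units; beyond the scatter), the larger of the two new steps, which shows that the identity of the halogen at this place matters, something the earlier steps, both within the scatter, could not reveal. Nothing shown here accounts for why fluoro and chloro differ at this carbon.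

Going by these compounds, it remains open whether the higher number belongs to fluoro alone or would also appear with other small groups at this carbon, such as bromo, methyl or methoxy. On these data alone, it is equally open whether fluoro would give a similar step at the carbon that carries the chloro in compound 2, so the result speaks for one place on the ring only.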